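Trading a saturated ring for an aromatic one at the imidazole arm

This account rests on a few compounds, and the source may have more. Where it says the series, first, only, none or still open, it means among the compounds named here.

Three compounds share one core and differ only in the ring carried on a saturated chain carbon bound to an aromatic carbon. Compound 1 `O=C(O)c1ccccc1-c1ccc(CCc2ncc(CC3CCOCC3)[nH]2)cc1` carries oxan-4-yl there and in an in vitro functional assay on cells for agonist activity at Bombesin receptor subtype-3 (Homo sapiens), read by luminescence and calcium flux (a higher number here means that more compound is needed for the effect, a lower number that less compound is needed), compound 1 gives 338 nM. Compound 2 `O=C(O)c1ccccc1-c1ccc(CCc2ncc(CC3CCCCCC3)[nH]2)cc1` carries cycloheptyl and gives 88 nM. Compound 3 `O=C(O)c1ccccc1-c1ccc(CCc2ncc(CC3CCCCC3)[nH]2)cc1` carries cyclohexyl and gives 41 nM, the lowest number of the three: the step of an 8.2-fold lower number from compound 1 to compound 3 (0.92 log units; beyond the scatter) and the step of a 2.1-fold lower number from compound 2 to compound 3 (0.33 log units; beyond the scatter) are both beyond the scatter, and the step of a 3.8-fold lower number from compound 1 to compound 2 (0.58 log units; beyond the scatter) shows that the choice of ring at this position shifts the read-out.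

Compound 4 `COc1ccccc1Cc1cnc(CCc2ccc(-c3ccccc3C(=O)O)cc2)[nH]1` has not been measured. Its change from compound 3 is 2-methoxyphenyl in place of cyclohexyl on a saturated chain carbon bound to an aromatic carbon; cut one bond further out, it reads cyclohexylmethyl to 2-methoxybenzyl. Among the compounds with values here, no measured step swaps a saturated ring for an aromatic one here, so the three steps above only show that this position is sensitive and that the oxygen-containing oxan-4-yl gave the highest number. A modest rise in the number is therefore expected for compound 4, in the step of a 3.2-fold higher number from compound 3 to compound 4 (0.50 log units; beyond the scatter), with wide uncertainty. Compound 4 is estimated at 130 nM, between 40 nM and 450 nM.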

Compound 4, half-maximal effective concentration: 1720 nM
The estimate for compound 4 lay 13-fold (1.12 log units) below the measured number; measured number outside the range, above it.
By their numbers in this assay, from the lowest: compound 3; then compound 2; then compound 1; then compound 4.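

In this assay the swap to 2-methoxyphenyl gives a 42-fold higher number from compound 3 to compound 4 (1.62 log units; beyond the scatter) and a 20-fold higher number from compound 2 to compound 4 (1.29 log units; beyond the scatter) and both of these large steps exceed anything seen among the saturated rings. Within the data shown here, the oxan-4-yl group had given the highest number so far, yet the new group goes past it too, with a 5.1-fold higher number from compound 1 to compound 4 (0.71 log units; beyond the scatter) as the smallest of the three new steps. This position therefore tolerates far less than the saturated rings alone suggested: all three of them give lower numbers than the single aromatic ring shown, with no compound here going against that, although one aromatic example cannot establish a rule for aromatic rings in general.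

The change brings in an aromatic ring and a methoxy group at once, so the compounds shown cannot tell how much of the rise belongs to each, and a plain phenyl group on the same saturated chain carbon would be needed to separate the two. Nothing available here accounts for the size of the rise.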